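This account rests on a few compounds, and the source may have more. Where it says the series, first, only, none or still open, it means among the compounds named here.

Compound 1 `CCC(C)Sc1nc(C(C)c2c(F)cccc2Cl)c(C)c(=O)[nH]1`: > 1500 nM
Compound 2 `Cc1c(C(C)c2c(F)cccc2Cl)nc(SC2CCCC2)[nH]c1=O`: > 15000 nM
Compound 3 `CCc1c(C(C)c2c(F)cccc2Cl)nc(SC2CCCC2)[nH]c1=O`: > 3000 nM

All three entries in an ADME assay on MT4 cells (Homo sapiens) for activation, read by MTT assay (a higher number here means that more compound is tolerated, a lower number that less compound is tolerated), are limits and not numbers. Compound 2 stands at the limit of > 15000 nM in this assay, at which 1 of the 3 values shown sits, so it has no exact value. Compound 4 `CCC(c1nc(SC2CCCC2)[nH]c(=O)c1C)c1c(F)cccc1Cl` has not yet been measured. Measured against compound 2, it shows this difference: methyl in place of hydrogen on a saturated chain carbon, two bonds along the chain from two aromatic carbons. Cut one bond further out, the same difference reads methyl to ethyl.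

Within the data shown here, two measured steps bear on this change. The closer one is also methyl in place of hydrogen, though at another place: a step that the two limits leave unreadable from compound 2 to compound 3. The other concerns the group on sulfur: a step that the two limits leave unreadable from compound 1 to compound 2. Neither gives a size or a direction to carry over, so no step beyond the scatter is expected in this assay, and the margin stays wide. The expected step is a number no higher from compound 2 to compound 4 (the limit leaves the size open) (an estimate only). Compound 4 is estimated at 15000 nM, with an expected range from 3000 nM to 60000 nM, and it may well be reported as a limit.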

Compound 4, half-maximal cytotoxic concentration: > 3000 nM
Compound 4 gave a limit, no number; the forecaster's own chance of this, stated with the estimate: 80%; the middle value does not contradict the limit.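

In this assay compound 4 gives > 3000 nM, which is a limit and not a number. Among these compounds, compound 2 also has only a limit, so no step between compound 2 and compound 4 can be read. The compounds shown leave open whether methyl in place of hydrogen at this place changes the half-maximal cytotoxic concentration at all.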